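From 3-Fluorophenyl to 4-Fluorophenyl

The compounds below may be only part of what the source reports. "The series", "measured", "known", "first", "only" and "open" are said of these compounds alone.

In a functional assay on M21 cells (Homo sapiens) for antiproliferative activity, read by sulforhodamine B assay, with a stated time of 48 h (a lower number here means a stronger inhibitor, a higher number a weaker inhibitor), compound 1 (`CCCN1CCN(c2ccc(S(=O)(=O)Oc3c(Cl)cc(Cl)cc3Cl)cc2)C1=O`) gives 56000 nM, while compound 2 (`CCCN1CCN(c2ccc(S(=O)(=O)Oc3cccc(F)c3)cc2)C1=O`) gives 12000 nM, the lower of the two numbers. Compound 3 (`CCCN1CCN(c2ccc(S(=O)(=O)Oc3ccc(F)cc3)cc2)C1=O`) has 4-fluorophenyl in place of 3-fluorophenyl on an oxygen. Going by the values given here, the only measured step, a 4.7-fold lower number from compound 1 to compound 2 (0.67 log units; beyond the scatter), exchanged 2,4,6-trichlorophenyl for 3-fluorophenyl, so it bears only indirectly on this change. No step beyond the scatter is therefore expected in this assay. The expected change is small, a 1.2-fold lower number from compound 2 to compound 3 (0.08 log units; within the scatter). Compound 3 is expected at 10000 nM, with an estimated range of 4000 nM to 25000 nM.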

Compound 3, half-maximal inhibitory concentration: 14000 nM
The estimate for compound 3 lay 1.4-fold (0.15 log units) below the measured number; measured number inside the range.
By their numbers in this assay, from the lowest: compounds 2 and 3 (each within the scatter of the next); then compound 1.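

In this assay, 4-fluorophenyl in place of 3-fluorophenyl on the oxygen bonded to the sulfonyl sulfur gives a 1.2-fold higher number from compound 2 to compound 3 (0.07 log units; within the scatter), so this assay does not separate the two fluorophenyl groups at this position. The step from the 2,4,6-trichlorophenyl group to 4-fluorophenyl, a 4.0-fold lower number from compound 1 to compound 3 (0.60 log units; beyond the scatter), runs in the same direction as the step to 3-fluorophenyl. Nothing available gives a reason for either step.

The compounds shown leave open how an unsubstituted phenyl or a 4-methoxyphenyl group would read on this oxygen. They also leave open whether a butyl chain in place of the propyl chain would change the number.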